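Sulfoxide Swap on the Imidazole Series: Cytotoxicity Outlook

A few compounds are considered here, and "the series" means these few. Any claim that something is new, unique, unknown or untested is made for them only; others in the source may bear on it.

Compound 1 `CCOC(=O)c1cc2c(CN3CCCC3)c(O)c(OC)cc2nc1C[S+]([O-])c1ccc(F)c(F)c1`: 16.5 uM
Compound 2 `CCOC(=O)c1cc2c(Cn3ccnc3)c(O)c(OC)cc2nc1CSc1ccc(F)cc1`: 202 uM
Compound 3 `CCOC(=O)c1cc2c(Cn3ccnc3)c(O)c(OC)cc2nc1CSc1cccc(OC)c1`: 187 uM

In an ADME assay on HepG2 2.2.15 cells (Homo sapiens) for cytotoxicity, read by MTT assay, with a stated time of 9 days (on this read-out higher numbers stand for lower toxicity in this test and lower numbers for higher toxicity in this test), compound 3 gives 187 uM, the second highest of the three numbers; compound 2 sits within the scatter of it, while compound 1 gives 16.5 uM, well apart. Compound 4 `CCOC(=O)c1cc2c(Cn3ccnc3)c(O)c(OC)cc2nc1C[S+]([O-])c1ccc(F)c(F)c1` is not yet measured. It differs from compound 3 in this way: a group of 10 heavy atoms (6 carbon, 1 oxygen, 2 fluorine, 1 sulfur; one six-membered aromatic ring of carbon only) in place of a group of 9 heavy atoms (7 carbon, 1 oxygen, 1 sulfur; one six-membered aromatic ring of carbon only), on a saturated chain carbon bound to an aromatic carbon. Among the measured compounds shown here, the only measured step, a 1.1-fold lower number from compound 2 to compound 3 (0.03 log units; within the scatter), exchanged one aryl group for another on the sulfur and changed little. For the measured compounds named here, no step covers the sulfoxide or the fluorine pattern; compound 1, which carries the same group as compound 4 but a different attachment elsewhere, shows a markedly lower number than compounds 2 and 3. Compound 4 is therefore expected to land between them, estimated at 60 uM (range 15 uM to 220 uM), a step of a 3.1-fold lower number from compound 3 to compound 4 (0.49 log units; beyond the scatter).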

Compound 4, half-maximal toxic concentration: 90.8 uM
Beside the measured number, compound 4's estimate is 1.5-fold (0.18 log units) below it, and the stated range covers the measured number.
By their numbers in this assay, from the lowest: compound 1; then compound 4; then compounds 3 and 2 (each within the scatter of the next).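

In this assay, the group carrying the sulfoxide and two fluorines gives a modest drop on the saturated chain carbon, with a 2.1-fold lower number from compound 3 to compound 4 (0.31 log units; beyond the scatter) and a 2.2-fold lower number from compound 2 to compound 4 (0.35 log units; beyond the scatter) as the two readings. With that group held fixed, 1H-imidazol-1-yl in place of pyrrolidin-1-yl gives a 5.5-fold higher number from compound 1 to compound 4 (0.74 log units; beyond the scatter) so the other attachment also moves the number. No measured evidence accounts for these shifts.

The compounds shown leave open whether the sulfoxide or the fluorine pattern drives the drop on the sulfur side. Going by these compounds, how a morpholine or a piperidine would read at the imidazole attachment also remains open.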